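A Second Chlorine on the Shared Core

The compounds below may be only part of what the source reports. "The series", "measured", "known", "first", "only" and "open" are said of these compounds alone.

Measured compounds:
compound 1 `ClCc1ccccc1Cn1cnc2c(Cl)nc(Cl)nc21`: 350 nM
compound 2 `ClCc1ccccc1Cn1cnc2ncnc(Cl)c21`: 4670 nM
compound 3 `ClCc1ccc(Cn2cnc3c(Cl)nc(Cl)nc32)cc1`: 17400 nM

In a functional assay on SW-620 cells (Homo sapiens) for cytotoxicity, read by sulforhodamine B assay, with a stated time of 48 h (on this read-out higher numbers stand for weaker inhibition of growth and lower numbers for stronger inhibition of growth), compound 2 stands second highest of the three numbers. Compound 3 sits nearest to it, with a higher number, and compound 1 lies furthest, with a much lower number; both gaps are beyond the scatter.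

Compound 4 `ClCc1ccccc1Cn1cnc2nc(Cl)nc(Cl)c21` differs from compound 2 by chloro in place of hydrogen on an aromatic carbon. Among the compounds with values here, no measured pair shows this exact change, so the expectation rests on the whole set. Some support for a gain comes from compound 1, which carries two chloro groups and gives 350 nM in this assay, though its core arrangement differs. The expected step is a 3.1-fold lower number from compound 2 to compound 4 (0.49 log units; beyond the scatter), toward stronger inhibition of growth. Compound 4 is estimated at 1500 nM, with a range from 400 nM to 6000 nM.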

Compound 4, concentration for total growth inhibition: 670 nM
Compound 4: the middle estimate sits 2.2-fold (0.35 log units) above what was measured, and the stated range covers the measured number.
By their numbers in this assay, from the lowest: compounds 1 and 4 (each within the scatter of the next); then compound 2; then compound 3.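

In this assay putting chloro in place of hydrogen on the aromatic carbon between two ring nitrogen atoms gives a 7.0-fold lower number from compound 2 to compound 4 (0.84 log units; beyond the scatter) toward stronger inhibition of growth. Within the data shown here, this is the first pair here that differs in one place, so the gain can be tied to this single change on the shared core. No measurement shown accounts for the gain.

On these data alone, only hydrogen and chloro appear at this position, so the step an amine or a methoxy group would give there stays open. So does whether the gain would persist with a longer chain in place of the chloromethyl group.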